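The source may hold more compounds than are shown below. What is called first, only, known or untested is meant among the compounds shown, and "the series" means these compounds.

Compound 2 `Nc1sc(-c2ccc(Cl)cc2)c(-c2ccc(Cl)cc2)c1C(=O)N1CCCC1` stands at the lower of two numbers in a functional assay on PC-3 cells (Homo sapiens) for cytotoxicity, read by sulforhodamine B assay, with a stated time of 72 h (on this read-out higher numbers stand for weaker inhibition and lower numbers for stronger inhibition), where compound 2 gives 6220 nM. Its neighbour, compound 1 `Nc1sc(-c2ccc(Cl)cc2)c(-c2ccc(Cl)cc2)c1C(=O)NC1CCCCC1`, gives 7300 nM in this assay, and the change from compound 1 to compound 2 produced a 1.2-fold lower number from compound 1 to compound 2 (0.07 log units; within the scatter). Compound 3 `Nc1sc(-c2ccc(Cl)cc2)c(-c2ccc(Cl)cc2)c1C(=O)NC1CC1` carries cyclopropylamino in place of pyrrolidin-1-yl on a carbonyl carbon. Among the compounds with values here, the one step that bears on this change, the amide exchange between compound 1 and compound 2, stayed within the scatter, so the shift from compound 2 to compound 3 is expected to be a 1.1-fold higher number from compound 2 to compound 3 (0.05 log units; within the scatter), with no direction beyond the scatter. Compound 3 is therefore estimated at 7000 nM, between 3500 nM and 14000 nM.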

Compound 3, half-maximal inhibitory concentration: 3680 nM
Compound 3: middle estimate off by 1.9-fold (0.28 log units), on the high side; low and high end bracket the measured number.
By their numbers in this assay, from the lowest: compounds 3, 2 and 1 (each within the scatter of the next).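

Across this amide position in this assay, cyclopropylamino in place of pyrrolidin-1-yl gives a 1.7-fold lower number from compound 2 to compound 3 (0.23 log units; within the scatter) and cyclopropyl in place of cyclohexyl on the amide-type nitrogen gives a 2.0-fold lower number from compound 1 to compound 3 (0.30 log units; within the scatter) with both steps printed as within the scatter. The position thus shows no measurable preference among these three ring-bearing amides, even with the smallest ring included. No evidence on hand bears on these results. The compounds shown leave open whether an open-chain amide such as a longer alkyl chain, or a ring carrying an amine or a carboxylic acid, would move the number beyond the scatter.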